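Working notes: phenyl for 2-phenylethenyl on a carbonyl carbon

A few compounds are considered here, and "the series" means these few. Any claim that something is new, unique, unknown or untested is made for them only; others in the source may bear on it.

Measured so far:
- Compound 1 `CSc1cnc2ccccc2c1SCC#CCOC(=O)/C=C/c1ccccc1` gives 18.1 ug/mL in a functional assay on CCRF-CEM cells (Homo sapiens) for antiproliferative activity, with a stated time of 72 h; on this read-out lower numbers stand for stronger inhibition and higher numbers for weaker inhibition.
- Compound 2 `C#CCSc1cnc2ccccc2c1SCC#CCOC(=O)/C=C/c1ccccc1` gives 50.9 ug/mL in this assay.

For the measured compounds named here, compound 1 stands lowest of the two numbers in this assay; its nearest neighbour is compound 2, and the one step so far, a 2.8-fold higher number from compound 1 to compound 2 (0.45 log units; beyond the scatter), concerns the replacement of hydrogen by ethynyl on a saturated chain carbon bound to a sulfur, a modest change that lies beyond the scatter.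

Compound 3 `CSc1cnc2ccccc2c1SCC#CCOC(=O)c1ccccc1` is the next compound in the series. It differs from compound 1 by phenyl in place of 2-phenylethenyl on a carbonyl carbon. Going by the values given here, no measured step touches this carbonyl carbon: the only step so far changes a different place in the shared core, so it gives no direct guide to the present change. In the absence of any comparable step, no step beyond the scatter is expected in this assay, and the range around the estimate is kept wide in both directions.

Compound 3 is therefore expected to give 22 ug/mL in this assay, that is a step of a 1.2-fold higher number from compound 1 to compound 3 (0.08 log units; within the scatter), between 9 ug/mL and 55 ug/mL.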

Compound 3, concentration for 50% inhibition: 22.2 ug/mL
Estimate against measurement, compound 3: 1.0-fold (0.00 log units) below; the range from low to high includes it.
By their numbers in this assay, from the lowest: compounds 1 and 3 (each within the scatter of the next); then compound 2.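

With phenyl in place of 2-phenylethenyl on a carbonyl carbon, this assay gives a 1.2-fold higher number from compound 1 to compound 3 (0.09 log units; within the scatter), so the two groups cannot be told apart at this position in this read-out. For the compounds shown here, for compounds 1 and 3, the double bond outside aromatic rings that leaves with 2-phenylethenyl is therefore not needed to keep the number in this range, while the only step beyond the scatter so far remains a 2.8-fold higher number from compound 1 to compound 2 (0.45 log units; beyond the scatter), which lies at a different place in the shared core. No measurement bearing on this result is available to explain it.

Open, from the compounds shown here alone, is whether a group without an aromatic ring on this carbonyl carbon, such as methyl or a longer alkyl chain, or a phenyl carrying an amine or a carboxylic acid, would stay within the scatter of compound 1 in this assay. Also open, going by these compounds, is whether phenyl and 2-phenylethenyl would remain indistinguishable at this carbonyl carbon with the ethynyl-bearing chain of compound 2 on the sulfur.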